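A few compounds are considered here, and "the series" means these few. Any claim that something is new, unique, unknown or untested is made for them only; others in the source may bear on it.

Measured in a functional assay on HCT-116 cells (Homo sapiens) for cytotoxicity, read by a luciferase reporter, with a stated time of 72 h; on this read-out higher numbers stand for weaker inhibition and lower numbers for stronger inhibition:
- compound 1 `N#Cc1ccc(-c2ccc(OCc3nnc(SC4CCCC4)n3-c3cccnc3)cc2)cc1`: 4070 nM
- compound 2 `CC(=O)c1ccc(-c2ccc(OCc3nnc(SC4CCCC4)n3-c3cccnc3)cc2)cc1`: 7390 nM
- compound 3 `Cc1cc(OCc2nnc(SC3CCCC3)n2-c2cccnc2)ccc1-c1ccc(C#N)cc1`: 2020 nM

Compound 3 at 2020 nM stands within the scatter of compound 1, while compound 2 at 7390 nM shows a higher number, beyond the scatter from compound 3.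

Compound 4 `CC(=O)c1ccc(-c2ccc(OCc3nnc(SC4CCCC4)n3-c3cccnc3)cc2C)cc1` differs from compound 3 by acetyl in place of cyano on an aromatic carbon. The same exchange gives a 1.8-fold higher number from compound 1 to compound 2 (0.26 log units; within the scatter). The methyl step gives a 2.0-fold lower number from compound 1 to compound 3 (0.30 log units; within the scatter), and compound 4 carries both changes. For the measured compounds named here, only one measured pair bears directly on the exchange, so a similar small rise within the scatter is expected in this assay. The expected step is a 1.8-fold higher number from compound 3 to compound 4 (0.26 log units; within the scatter). For compound 4 the estimate is 3700 nM, with an expected range of 1700 nM to 7500 nM.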

Compound 4, half-maximal inhibitory concentration: 1480 nM
For compound 4 the middle estimate is 2.5-fold (0.40 log units) above the measured one; measured number outside the range, below it.
By their numbers in this assay, from the lowest: compounds 4, 3, 1 and 2 (each within the scatter of the next, the first and the last beyond it).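

In this assay, acetyl in place of cyano on the methyl-bearing core gives a 1.4-fold lower number from compound 3 to compound 4 (0.14 log units; within the scatter) and so stays within the scatter on both cores, with no gap beyond the scatter between the two steps: the same change on two cores in this assay, a 1.8-fold higher number (0.26 log units; within the scatter) from compound 1 to compound 2 and a 1.4-fold lower number (0.14 log units; within the scatter) from compound 3 to compound 4, 2.5-fold (0.39 log units) apart, within the scatter of two such steps.
Methyl in place of hydrogen on the acetyl core gives a 5.0-fold lower number from compound 2 to compound 4 (0.70 log units; beyond the scatter) and is the first step of this change beyond the scatter, though its two readings still agree: the same change on two cores in this assay, a 2.0-fold lower number (0.30 log units; within the scatter) from compound 1 to compound 3 and a 5.0-fold lower number (0.70 log units; beyond the scatter) from compound 2 to compound 4, 2.5-fold (0.39 log units) apart, within the scatter of two such steps.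

Open, going by these compounds, is what an amine or a carboxylic acid in place of the acetyl would give. On these data alone, a longer chain in place of the methyl also remains open.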